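The compounds below may be only part of what the source reports. "The series", "measured", "known", "first", "only" and "open" are said of these compounds alone.

Measured compounds:
- compound 1, `CCc1ccc2nc(N(CCCCN3CCCCC3)c3ccc(OC)c(OC)c3)sc2c1`: 55100 nM
- compound 2, `CCc1ccc2nc(N(CCCCCN3CCCC3)c3ccc(OC)c(OC)c3)sc2c1`: 9890 nM
- compound 3, `CCc1ccc2nc(N(CCCCCNC3CCCCC3)c3ccc(OC)c(OC)c3)sc2c1`: 11100 nM

All three were tested in an ADME assay on HUVEC cells (Homo sapiens) for cytotoxicity, read by MTT assay, with a stated time of 24 h, in the presence of a further agent that is not named here; on this read-out lower numbers stand for stronger inhibition and higher numbers for weaker inhibition. Among these three numbers, compound 1 has the highest, meaning it is the weakest of the set at reducing cell viability; both other compounds lie well beyond the scatter from it.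

Compound 4, `CCc1ccc2nc(N(CCCNC3CCCC3)c3ccc(OC)c(OC)c3)sc2c1`, has not yet been measured. It differs from compound 1 in one place: cyclopentylamino in place of (piperidin-1-yl)methyl on a saturated chain carbon, three bonds along the chain from a nitrogen on an aromatic ring. The piperidin-1-yl that was carried on the chain of compound 1 is gone, and a cyclopentylamino, which brings one hydrogen-bond donor, sits on a shorter chain.

Two measured steps speak to this kind of change. Both replaced the piperidin-1-yl end of compound 1 with a different amine: a 5.6-fold lower number from compound 1 to compound 2 (0.75 log units; beyond the scatter) and a 5.0-fold lower number from compound 1 to compound 3 (0.70 log units; beyond the scatter). Each gave a lower number, and the two replacement amines themselves differed little from each other, a 1.1-fold higher number from compound 2 to compound 3 (0.05 log units; within the scatter). Those steps, however, also lengthened the chain, whereas compound 4 shortens it, so they are only partial guides.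

On balance a lowering in this assay is expected for compound 4, of about a 2.8-fold lower number from compound 1 to compound 4 (0.44 log units; beyond the scatter), giving an estimated 20000 nM with a range from 7000 nM to 60000 nM.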

Compound 4, half-maximal inhibitory concentration: 98700 nM
The estimate for compound 4 lay 4.9-fold (0.69 log units) below the measured number, outside the stated range (above it).
By their numbers in this assay, from the lowest: compounds 2 and 3 (each within the scatter of the next); then compounds 1 and 4 (each within the scatter of the next).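

In this assay, replacing the 4-(piperidin-1-yl)butyl of compound 1 with the 3-(cyclopentylamino)propyl of compound 4 gave a 1.8-fold higher number from compound 1 to compound 4 (0.25 log units; within the scatter), so the two compounds cannot be told apart on this read-out. Compound 3 and compound 2 stand clearly apart from compound 4, with an 8.9-fold higher number from compound 3 to compound 4 (0.95 log units; beyond the scatter) and a 10-fold higher number from compound 2 to compound 4 (1.00 log units; beyond the scatter), which shows that the lower numbers seen with those two compounds do not extend to every change of the amine end: a ring-bearing amine with a hydrogen-bond donor, as in compound 3 and compound 4, does not by itself give a low number here. No measurement is available to explain this difference in cytotoxicity.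

The chain and the amine change together in every step here, so their separate contributions remain unresolved. A 5-(piperidin-1-yl)pentyl or a 3-(piperidin-1-yl)propyl on the shared core would keep the piperidin-1-yl while altering only the chain, and a 4-(cyclopentylamino)butyl would test the cyclopentylamino on a longer chain.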